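The compounds below may be only part of what the source reports. "The series", "measured", "known", "first", "only" and "open" are said of these compounds alone.

Measured so far in an assay on isolated protein for binding affinity to 5-hydroxytryptamine receptor 1D (Homo sapiens); on this read-out higher numbers stand for weaker inhibition and lower numbers for stronger inhibition: compound 1 `COc1cc2c(cc1N1C[C@@H](C)N(C)[C@@H](C)C1)N(C(=O)c1cccc(Cl)c1Cl)CC2` gives 251 nM; compound 2 `COc1cc2c(cc1N1C[C@@H](C)N(C)[C@@H](C)C1)N(C(=O)Nc1cccc(Cl)c1Cl)CC2` gives 79.4 nM; compound 3 `COc1cc2c(cc1N1C[C@@H](C)N(C)[C@@H](C)C1)N(C(=O)c1ccc(-c3cccc(C)n3)c3ccccc13)CC2` gives 100 nM.

Compound 2 has the lowest of the three numbers. Compound 3 lies within the scatter of compound 2, so no order between the two can be claimed. Among the compounds with values here, compound 1 stands apart: a 3.2-fold lower number from compound 1 to compound 2 (0.50 log units; beyond the scatter), the only single-point step among the measured compounds, and it concerns the carbonyl side of the shared core, not the halogen pattern on the aryl ring.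

Compound 4 `COc1cc2c(cc1N1C[C@@H](C)N(C)[C@@H](C)C1)N(C(=O)Nc1cccc(Cl)c1F)CC2` differs from compound 2 by fluoro in place of chloro on an aromatic carbon. Within the data shown here, no measured pair changes a halogen on that ring, so nothing here bears directly on the step. In the absence of any relevant step, the expectation is a change that stays within the scatter, a 1.4-fold higher number from compound 2 to compound 4 (0.14 log units; within the scatter), with the direction undetermined. Compound 4 is therefore expected near 110 nM in this assay, with a range of 40 nM to 300 nM.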

Compound 4, inhibition constant: 200 nM
The estimate for compound 4 lay 1.8-fold (0.26 log units) below the measured number; the measured number falls inside the stated range.
By their numbers in this assay, from the lowest: compounds 2, 3, 4 and 1 (each within the scatter of the next, the first and the last beyond it).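

In this assay, the halogen on the aromatic carbon ortho to a chloro group proves to matter: fluoro in place of chloro gives a 2.5-fold higher number from compound 2 to compound 4 (0.40 log units; beyond the scatter), the first halogen change read in this series. With (3-chloro-2-fluorophenyl)amino on the carbonyl carbon, the number no longer separates from that of the 2,3-dichlorophenyl compound, with a 1.3-fold lower number from compound 1 to compound 4 (0.10 log units; within the scatter), whereas (2,3-dichlorophenyl)amino had given a 3.2-fold lower number from compound 1 to compound 2 (0.50 log units; beyond the scatter). No measurement at hand explains why this halogen change shifts the number.

From the compounds shown here alone, whether a bromo or methyl group at the same place would follow chloro or fluoro remains open. Also open, going by these compounds, is whether the same fluoro for chloro change would give a step of like size with the aryl group attached directly to the carbonyl carbon.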